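The source may report more compounds than this note shows. Statements on the series, on what has been measured and on what is new or still open speak of the compounds shown alone.

Compound 1 `O/N=C(\CCN1CCN(c2ccccn2)CC1)c1ccccc1` was tested in a functional assay on HEK293 cells with D(4) dopamine receptor (Homo sapiens) as the target, read by FLIPR (a lower number here means a smaller maximal response, a higher number a larger maximal response), where compound 1 gives 70%. Compound 2 `O/N=C(\CCN1CCN(c2ccccn2)CC1)c1cc(F)cc(F)c1` differs from it only at the ring on the carbon with a double bond to nitrogen, and in this assay compound 2 gives 74%. Among the measured compounds shown here, these two numbers cannot be told apart: the step of a number 4 percentage points higher from compound 1 to compound 2 (within the scatter) stays inside the scatter, so compound 1 stands level with the only other measured compound. Compound 3 `O/N=C(\CCN1CCN(c2nccs2)CC1)c1ccccc1` carries a change at a different place: 1,3-thiazol-2-yl in place of pyridin-2-yl on an amine nitrogen in a ring. For the measured compounds named here, no measured step touches this amine nitrogen in a ring; the single step known concerns the other end of the molecule and did not move the number beyond the scatter. The data therefore give no reason to expect a change beyond the scatter, and the expected step in this assay is no change at the digits printed from compound 1 to compound 3 (within the scatter). For compound 3 the estimate is 70%, within a range from 55% to 85%.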

Compound 3, largest response reached (reported as efficacy), in percent of the reference or control that the assay uses: 44%
For compound 3 the middle estimate is 26 percentage points above the measured one; the measured number lies below the stated range.
By their numbers in this assay, from the lowest: compound 3; then compounds 1 and 2 (each within the scatter of the next).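

In this assay, the group on the amine nitrogen in a ring proves to matter: 1,3-thiazol-2-yl in place of pyridin-2-yl gives a number 26 percentage points lower from compound 1 to compound 3 (beyond the scatter). Among the compounds shown here, the only earlier step, at the ring on the carbon with a double bond to nitrogen, gave a number 4 percentage points higher from compound 1 to compound 2 (within the scatter), so this is the first change seen to move the maximal response beyond the scatter. No independent measurement is available to explain the drop.

The change replaces a six-membered aromatic ring with a five-membered one and also brings in sulfur, so these compounds cannot show which of these differences counts. As far as these compounds go, a plain phenyl or a 1,3-oxazol-2-yl group on the same nitrogen would help separate them, and whether the same drop occurs with 3,5-difluorophenyl on the other ring remains open.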